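The source may hold more compounds than are shown below. What is called first, only, known or untested is meant among the compounds shown, and "the series" means these compounds.

In an ADME assay on MDBK cells (Bos taurus) for cytotoxicity, read by MTT assay, with a stated time of 96 h (a lower number here means that less compound is tolerated, a higher number that more compound is tolerated), compound 1 `CN(/N=N/c1ccccc1)c1ccccc1` gives only a limit, > 100000 nM, and not a number. Among the measured compounds shown here, compound 2 `CN(C)CCCN(/N=N/c1cccc([N+](=O)[O-])c1)c1ccccc1` gives 37000 nM, the only true number so far. Compound 3 `CN(C)CCCN(/N=N/c1ccccc1)c1ccccc1` differs from compound 2 in one place: hydrogen in place of nitro on an aromatic carbon. For the measured compounds named here, no measured pair of compounds isolates this change, so the expectation stays cautious. The step of a 1.4-fold higher number from compound 2 to compound 3 (0.13 log units; within the scatter) is expected to be small, near the usual scatter, and if anything towards more compound tolerated. For compound 3 the estimated value is 50000 nM, with an expected range from 20000 nM to 100000 nM.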

Compound 3, half-maximal cytotoxic concentration: 95000 nM
Estimate against measurement, compound 3: 1.9-fold (0.28 log units) below, and the stated range covers the measured number.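

In this assay, among the compounds shown here, hydrogen in place of nitro on an aromatic carbon gives a 2.6-fold higher number from compound 2 to compound 3 (0.41 log units; beyond the scatter), a modest step, and so shows, for the first time at this position, that more compound is tolerated without the nitro. With 2-(dimethylamino)ethyl in place of hydrogen on a saturated chain carbon bound to a nitrogen on an aromatic ring, the data give an at least 1.0-fold lower number from compound 1 to compound 3 (0.02 log units; that floor lies within the scatter), and this is only a floor, because compound 1 stands at a limit of the assay, not at a number: the limit of > 100000 nM in this assay, at which 1 of the 3 values shown sits. Still open, as far as these compounds go, is how an amine or a carboxylic acid on the same aromatic carbon would compare with nitro and hydrogen. Also open, from the compounds shown here alone, is whether a longer chain in place of the 2-(dimethylamino)ethyl would change the tolerated amount.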